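The source may hold more compounds than are shown below. What is called first, only, known or untested is meant among the compounds shown, and "the series" means these compounds.

Compound 1 `CC(C)n1ncc2c(C(=O)Nc3ccccc3F)cc(-c3ccccn3)nc21`: 100000 nM
Compound 2 `CC(C)n1ncc2c(C(=O)Nc3ccc(F)cc3F)cc(-c3cccs3)nc21`: > 200000 nM

Both compounds were tested in an ADME assay on LLC-MK2 cells (Macaca mulatta) for cytotoxicity, read by spectrophotometry and crystal violet staining, with a stated time of 4 days; on this read-out lower numbers stand for higher toxicity in this test and higher numbers for lower toxicity in this test. Compound 1 gives a measured number, 100000 nM. Compound 2 gives > 200000 nM, which is a limit of the assay and not a number. Compound 2 therefore stands at the low-toxicity end of what has been reported so far.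

Compound 3 `CC(C)n1ncc2c(C(=O)Nc3ccccc3F)cc(-c3cccs3)nc21` differs from compound 2 in one place: hydrogen in place of fluoro on an aromatic carbon. Hydrogen takes the place of fluoro on an aromatic carbon, turning 2,4-difluorophenyl into 2-fluorophenyl. Going by the values given here, no measured step shows what this change does in this assay. A small move towards lower numbers is expected, possibly no larger than the usual scatter, as compound 1 gives 100000 nM. The estimated change is an at least 1.3-fold lower number from compound 2 to compound 3 (0.12 log units; that floor lies within the scatter). The expected value for compound 3 is 150000 nM, within an estimated range of 70000 nM to 300000 nM.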

Compound 3, half-maximal cytotoxic concentration: 50000 nM
Estimate against measurement, compound 3: 3.0-fold (0.48 log units) above; measured number below the stated range.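

Hydrogen in place of fluoro, para to a large group, gives an at least 4.0-fold lower number from compound 2 to compound 3 (0.60 log units; beyond the scatter) in this assay, the first direct reading of a change at this position. That size is only a floor, since compound 2 stands at a limit of the assay and not at a number: the limit of > 200000 nM in this assay, at which 1 of the 3 values shown sits.

Thiophen-2-yl in place of pyridin-2-yl reads a 2.0-fold lower number from compound 1 to compound 3 (0.30 log units; within the scatter), so compound 1 and compound 3 cannot be told apart in this test, and the change of the aromatic group has no clear effect here.

From the compounds shown here alone, what a chloro or methoxy group would give at this position remains open, as does the full size of the step from fluoro to hydrogen. Going by these compounds, it is also open whether the same change would give a similar step with pyridin-2-yl in place of thiophen-2-yl.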